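The source may hold more compounds than are shown below. What is called first, only, known or untested is meant among the compounds shown, and "the series" means these compounds.

Series notes. The shared core of compound 1 `COc1ccc(/C=C\c2cc(OC)c(OC)c(OC)c2)cc1OCc1ccc(C=O)cc1` carries a formyl group on the pendant benzyl ether ring. In an ADME assay on HEK293 cells (Homo sapiens) for cytotoxicity, read by CCK-8 assay, with a stated time of 48 h (on this read-out higher numbers stand for weaker inhibition and lower numbers for stronger inhibition), compound 1 gives 46000 nM, the higher of the two plain numbers recorded, with compound 3 `COc1ccc(/C=C\c2cc(OC)c(OC)c(OC)c2)cc1OCc1ccc(CO)cc1` nearest at 37000 nM, a 1.2-fold lower number from compound 1 to compound 3 (0.09 log units; within the scatter). In this assay compound 2 `COc1ccc(/C=C\c2cc(OC)c(OC)c(OC)c2)cc1OCc1ccc(CN[C@H](C(=O)O)[C@H](C)O)cc1` gives only a limit, > 50000 nM, and that is the limit of > 50000 nM in this assay, at which 1 of the 3 values shown sits. The change from formyl to the larger amine-bearing group gave an at least 1.0-fold higher number from compound 1 to compound 2 (0.03 log units; that floor lies within the scatter), and the pair of substituted compounds shows an at least 1.3-fold lower number from compound 2 to compound 3 (0.13 log units; that floor lies within the scatter).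

The step to compound 4 `COc1ccc(/C=C\c2cc(OC)c(OC)c(OC)c2)cc1OCc1ccc(CNCCN(C)C)cc1` is ((2-(dimethylamino)ethyl)amino)methyl in place of formyl on an aromatic carbon. Both earlier changes at this position, to hydroxymethyl and to ((1-carboxy-2-hydroxypropyl)amino)methyl, stayed within the scatter, so no shift beyond the scatter is expected here either, though the limit reached by compound 2 leaves the upper side open. Compound 4 is therefore estimated at 42000 nM (range 18000 nM to 100000 nM), which means an expected 1.1-fold lower number from compound 1 to compound 4 (0.04 log units; within the scatter).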

Compound 4, half-maximal inhibitory concentration: 39000 nM
Estimate against measurement, compound 4: 1.1-fold (0.03 log units) above; the measured number falls inside the stated range.
By their numbers in this assay, from the lowest: compounds 3, 4 and 1 (each within the scatter of the next). At a limit, above all of these: compound 2.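

With ((2-(dimethylamino)ethyl)amino)methyl on this aromatic carbon, para to a large group, an amine side chain without a carboxy group also stays within the scatter in this assay: a 1.2-fold lower number from compound 1 to compound 4 (0.07 log units; within the scatter), and a 1.1-fold higher number from compound 3 to compound 4 (0.02 log units; within the scatter). On the amine nitrogen, the exchange of 1-carboxy-2-hydroxypropyl for 2-(dimethylamino)ethyl gives an at least 1.2-fold lower number from compound 2 to compound 4 (0.10 log units; that floor lies within the scatter), so this pair fixes no size of change. Compound 2 stands at a limit and not at a number: the limit of > 50000 nM in this assay, at which 1 of the 4 values shown sits.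

No group shown at this position moves the number in this assay beyond the scatter. Open, on these data alone, is whether a cyclic amine such as piperidinylmethyl, a plain carboxylic acid or a longer chain on the amine nitrogen at this position would do so.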